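The source may hold more compounds than are shown below. What is called first, only, known or untested is meant among the compounds shown, and "the series" means these compounds.

Working notes on the nitro-thiochromenone series, cytotoxicity arm. Compound 1 `O=c1cc(N2CCN(CC3CCC(NS(=O)(=O)c4ccccc4)CC3)CC2)sc2c([N+](=O)[O-])cc(C(F)(F)F)cc12` was tested in an ADME assay on Vero cells (Chlorocebus sabaeus) for cytotoxicity, read by MTT assay, with a stated time of 48 h; on this read-out higher numbers stand for weaker inhibition and lower numbers for stronger inhibition. Compound 1 reached only the limit of this assay, > 64 ug/mL, so no number stands for it. Two analogues replace the (phenylsulfonyl)amino group on the same saturated ring carbon. Compound 2 `O=C(OC1CCC(CN2CCN(c3cc(=O)c4cc(C(F)(F)F)cc([N+](=O)[O-])c4s3)CC2)CC1)c1ccc2c(c1)OCC2` likewise stopped at the assay limit, > 64 ug/mL. Compound 3 `O=C(OC1CCC(CN2CCN(c3cc(=O)c4cc(C(F)(F)F)cc([N+](=O)[O-])c4s3)CC2)CC1)c1ccc(F)cc1` also stopped at the assay limit, > 64 ug/mL.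

Compound 4 `COc1ccc(C(=O)OC2CCC(CN3CCN(c4cc(=O)c5cc(C(F)(F)F)cc([N+](=O)[O-])c5s4)CC3)CC2)cc1` differs from compound 1 as follows: ((4-methoxyphenyl)carbonyl)oxy in place of (phenylsulfonyl)amino on a saturated ring carbon. The measured steps that bear on this change are those that exchange the same leaving group at the same saturated ring carbon, a step that the two limits leave unreadable from compound 1 to compound 2 and a step that the two limits leave unreadable from compound 1 to compound 3; the comparison among the entering esters, a step that the two limits leave unreadable from compound 2 to compound 3, is equally unreadable. The reason is the limit of > 64 ug/mL in this assay, at which 3 of the 3 values shown sit, which leaves no numbers to subtract. With no readable step in this assay for any exchange at this position, no step beyond the scatter is expected for compound 4 either; the step that the limit leaves unreadable from compound 1 to compound 4 is therefore estimated to be flat. Compound 4 is expected to give about 100 ug/mL in this assay, within 40 ug/mL to 250 ug/mL, most likely reported again as a limit rather than a number.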

Compound 4, half-maximal inhibitory concentration: > 64 ug/mL
Compound 4: only a limit was reported; the forecaster's own chance of this, stated with the estimate: 80%; the middle value does not contradict the limit.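

Compound 4 gives > 64 ug/mL in this assay, which is a limit and not a number. Among the compounds shown here, no step from compound 4 to compound 1, compound 2 or compound 3 can be read: the limit of > 64 ug/mL in this assay, at which 4 of the 4 values shown sit. The compounds shown leave open whether any exchange on the saturated ring carbon changes the read-out in this assay, and how far each compound lies past the limit.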